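The compounds below may be only part of what the source reports. "The series", "measured", "known", "first", "only" and "open" are said of these compounds alone.

Compound 3 `CC1=C(/C=C/C(C)=C/C=C/C(C)=C\C(=O)Nc2ccccc2O)C(C)(C)CCC1n1ccnc1` stands second highest of the three numbers in a functional assay on MCF7 cells (Homo sapiens) for inhibition, read by MTT assay (a lower number here means a stronger inhibitor of growth, a higher number a weaker inhibitor of growth), where compound 3 gives 1090 nM. Compound 1 `CC1=C(/C=C/C(C)=C/C=C/C(C)=C\C(=O)NCc2ccc(F)cc2)C(C)(C)CCC1n1ccnc1` gives 1930 nM in this assay, and compound 2 `CC1=C(/C=C/C(C)=C/C=C/C(C)=C\C(=O)NCc2ccc(O)cc2)C(C)(C)CCC1n1ccnc1` gives 160 nM. The step of a 1.8-fold lower number from compound 1 to compound 3 (0.25 log units; within the scatter) is small, whereas a 6.8-fold higher number from compound 2 to compound 3 (0.83 log units; beyond the scatter) is modest. Compound 4 `CC1=C(/C=C/C(C)=C/C=C/C(C)=C\C(=O)NCc2ccccc2)C(C)(C)CCC1n1ccnc1` differs from compound 3 by benzyl in place of 2-hydroxyphenyl on an amide-type nitrogen. The bearing steps are a 1.8-fold lower number from compound 1 to compound 3 (0.25 log units; within the scatter) and a 12-fold lower number from compound 1 to compound 2 (1.08 log units; beyond the scatter): compound 4 resembles compound 2 without its hydroxy, and compound 1 without its fluoro, so a number near that of compound 1 is expected. The step of a 1.7-fold higher number from compound 3 to compound 4 (0.22 log units; within the scatter) is therefore expected to be small. Compound 4 is estimated at 1800 nM in this assay, within 700 nM to 4500 nM.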

Compound 4, concentration for 50% growth inhibition: 9770 nM
Estimate against measurement, compound 4: 5.4-fold (0.73 log units) below; measured number outside the range, above it.
By their numbers in this assay, from the lowest: compound 2; then compounds 3 and 1 (each within the scatter of the next); then compound 4.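

In this assay, plain benzyl on the amide-type nitrogen proves no neutral baseline for the substituted benzyl compounds: losing the hydroxy gives a 61-fold higher number from compound 2 to compound 4 (1.79 log units; beyond the scatter), and losing the fluoro gives a 5.1-fold higher number from compound 1 to compound 4 (0.70 log units; beyond the scatter). Both substituents therefore go with lower numbers than hydrogen, the hydroxy by the larger step. The 2-hydroxyphenyl group also compares favourably with benzyl, with a 9.0-fold higher number from compound 3 to compound 4 (0.95 log units; beyond the scatter). Nothing available explains these shifts. On these data alone, whether a methoxy or an amine in place of the hydroxy of compound 2 would keep its low number remains open.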